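From compound 3 to compound 4: chloro for hydrogen

This account rests on a few compounds, and the source may have more. Where it says the series, first, only, none or still open, it means among the compounds named here.

Compound 1 `O=C(Nc1cccc(-c2ccccc2C(F)(F)F)c1)C(Cl)Cl`: 35900 nM
Compound 2 `Cc1ccccc1-c1cccc(NC(=O)C(Cl)Cl)c1`: 42000 nM
Compound 3 `O=C(Nc1cccc(-c2ccccc2)c1)C(Cl)Cl`: 46800 nM

These three compounds were tested in a functional assay on KB 3-1 cells (Homo sapiens) for cytotoxicity, read by MTT assay, with a stated time of 68 h (a lower number here means a stronger inhibitor, a higher number a weaker inhibitor), and their numbers cannot be told apart. Compound 3 stands level with both of the others. The two steps that reach it are a 1.1-fold higher number from compound 2 to compound 3 (0.05 log units; within the scatter) and a 1.3-fold higher number from compound 1 to compound 3 (0.12 log units; within the scatter).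

Compound 4 `O=C(Nc1cccc(-c2ccccc2Cl)c1)C(Cl)Cl` has not yet been measured. It has chloro in place of hydrogen on an aromatic carbon, ortho to a large group: chloro in place of hydrogen on an aromatic carbon. Among the measured compounds shown here, no measured compound carries chloro at that place, so the data offer only indirect guidance. The closest evidence comes from the exchanges among hydrogen, methyl and trifluoromethyl on that aromatic carbon. Besides the two steps already given, these include a 1.2-fold higher number from compound 1 to compound 2 (0.07 log units; within the scatter). None of the three exchanges moved the number beyond the scatter, so no step beyond the scatter is expected for chloro in this assay. The expected step is a 1.2-fold lower number from compound 3 to compound 4 (0.07 log units; within the scatter). The estimate for compound 4 is 40000 nM, with an expected range from 24000 nM to 62000 nM.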

Compound 4, half-maximal inhibitory concentration: > 50000 nM
Compound 4 ended at the assay's limit; the forecaster's own chance of this, stated with the estimate: 10%; middle value at least 1.2-fold (0.09 log units) away from the limit.
By their numbers in this assay, from the lowest: compounds 1, 2 and 3 (each within the scatter of the next). At a limit, above all of these: compound 4.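

In this assay compound 4 gives > 50000 nM as a limit of the assay and not as a number, the only such reading among the compounds shown: the limit of > 50000 nM in this assay, at which 1 of the 4 values shown sits.

Hydrogen, methyl and trifluoromethyl on this aromatic carbon, ortho to a large group, all gave readable numbers, so chloro is the first group at this place to reach the limit. Read as floors, the exchanges give an at least 1.0-fold higher number from compound 3 to compound 4 (0.02 log units; that floor lies within the scatter) and an at least 1.1-fold higher number from compound 2 to compound 4 (0.07 log units; that floor lies within the scatter) and an at least 1.3-fold higher number from compound 1 to compound 4 (0.14 log units; that floor lies within the scatter), and since each floor lies within the scatter, compound 4 is not shown to be a weaker inhibitor than any of the other three.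

On these data alone, how far compound 4 lies past the limit stays open, and with it whether chloro in place of hydrogen has any real effect at this position. The compounds shown also leave open what an amine or a carboxylic acid on this aromatic carbon would give, and whether any exchange here can move the number beyond the scatter in this assay.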